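From Pyridin-4-yl to 3-Fluorophenyl on a Shared Core

This account rests on a few compounds, and the source may have more. Where it says the series, first, only, none or still open, it means among the compounds named here.

In a functional assay on KB cells (Homo sapiens) for inhibition, with a stated time of 72 h (a lower number here means a stronger inhibitor, a higher number a weaker inhibitor), compound 1 `COc1ccc(S(=O)(=O)N2CCc3cccc(-c4ccco4)c32)cc1` gives 82 nM and compound 2 `COc1ccc(S(=O)(=O)N2CCc3cccc(-c4ccncc4)c32)cc1` gives 96 nM, so these two stand level within the scatter. Compound 3 `COc1ccc(S(=O)(=O)N2CCc3cccc(-c4cccc(F)c4)c32)cc1` has 3-fluorophenyl in place of pyridin-4-yl on an aromatic carbon. Among the measured compounds shown here, only one measured step bears on this change, a 1.2-fold higher number from compound 1 to compound 2 (0.07 log units; within the scatter), where pyridin-4-yl took the place of furan-2-yl and the size stayed within the scatter. Two compounds are thin evidence, but the expected step is a 1.1-fold lower number from compound 2 to compound 3 (0.03 log units; within the scatter), with no move beyond the scatter. For compound 3 the estimated value is 90 nM, with an expected range of 35 nM to 230 nM.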

Compound 3, half-maximal inhibitory concentration: 98.5 nM
For compound 3 the middle estimate is 1.1-fold (0.04 log units) below the measured one, and the stated range covers the measured number.
By their numbers in this assay, from the lowest: compounds 1, 2 and 3 (each within the scatter of the next).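

In this assay the change from pyridin-4-yl to 3-fluorophenyl gives (a 1.0-fold higher number from compound 2 to compound 3 (0.01 log units; within the scatter)), and the change from furan-2-yl to 3-fluorophenyl gives (a 1.2-fold higher number from compound 1 to compound 3 (0.08 log units; within the scatter)). At this position, then, a ring of carbon only with no hydrogen-bond acceptor stands level with the two rings that contain a hetero atom. No measurement shown here explains this level result. Going by these compounds, whether an amine, a carboxylic acid or a longer chain in this place would stay level remains open. So does whether any group here can move the number beyond the scatter.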